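The source may hold more compounds than are shown below. What is called first, only, known or untested is meant among the compounds shown, and "the series" means these compounds.

Measured so far:
compound 1 `O=C1/C(=C/c2ccccc2F)CN(S(=O)(=O)c2ccc(F)cc2)C/C1=C\c1ccccc1F` gives 8000 nM in a functional assay on HepG2 cells (Homo sapiens) for cytotoxicity, read by MTT assay, with a stated time of 24 h; a higher number here means a weaker inhibitor, a lower number a stronger inhibitor;
compound 2 `O=C1/C(=C/c2ccccc2F)CN(S(=O)(=O)c2ccc(Cl)cc2)C/C1=C\c1ccccc1F` gives 10900 nM in this assay;
compound 3 `O=C1/C(=C/c2ccc(F)cc2)CN(S(=O)(=O)c2ccc(F)cc2)C/C1=C\c1ccc(F)cc1` gives 8100 nM in this assay.

Compound 1 and compound 2 share a core and differ by chloro in place of fluoro on an aromatic carbon; the step is a 1.4-fold higher number from compound 1 to compound 2 (0.13 log units; within the scatter). Compound 3 is built from the same atoms as compound 1, joined differently; how the two cores differ is not broken down here. In this assay compound 3 and compound 1 give numbers within the scatter of each other, and the same holds against compound 2. Compound 4 `O=C1/C(=C/c2ccc(F)cc2)CN(S(=O)(=O)c2ccc(Cl)cc2)C/C1=C\c1ccc(F)cc1` is not yet measured. It differs from compound 3 by chloro in place of fluoro on an aromatic carbon, the same change as from compound 1 to compound 2, at a place described in the same words. The expectation rests on that single earlier instance, a 1.4-fold higher number from compound 1 to compound 2 (0.13 log units; within the scatter), which lies within the scatter. From compound 3 to compound 4 a step of a 1.4-fold higher number from compound 3 to compound 4 (0.13 log units; within the scatter) is expected. Compound 4 is estimated at 11000 nM, between 6000 nM and 20000 nM.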

Compound 4, half-maximal inhibitory concentration: 4500 nM
Compound 4: the middle estimate sits 2.4-fold (0.39 log units) above what was measured, and the stated range ends above it.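

In this assay, chloro in place of fluoro on the sulfonyl-bearing ring gives a 1.8-fold lower number from compound 3 to compound 4 (0.26 log units; within the scatter). Set beside the earlier step, the change shows no difference between the two cores that exceeds measurement noise: the same change on two cores in this assay, a 1.4-fold higher number (0.13 log units; within the scatter) from compound 1 to compound 2 and a 1.8-fold lower number (0.26 log units; within the scatter) from compound 3 to compound 4, 2.5-fold (0.39 log units) apart, within the scatter of two such steps. Going from (4-fluorophenyl)sulfonyl to (4-chlorophenyl)sulfonyl therefore gives no step beyond the scatter on either core, but this shows neither a shared effect of any size or direction nor a real dependence on the core.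

The compounds shown carry only fluoro or chloro at this place, so it remains open whether a methoxy, a nitrile or an amine there would give a step beyond the scatter. Going by these compounds, whether any such step would carry from one core to the other also remains open.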